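Phenoxy for Methoxy on Two Related Cores

The compounds below may be only part of what the source reports. "The series", "measured", "known", "first", "only" and "open" are said of these compounds alone.

Compound 1 `CCCn1ccc2cc(-c3ccc(OC)nc3)cc(Cl)c2c1=O` and compound 2 `CCCn1ccc2cc(-c3ccc(Oc4ccccc4)nc3)cc(Cl)c2c1=O` share one core, and compound 3 `CCCn1ccc2cc(-c3ccc(OC)cc3)cc(Cl)c2c1=O` and compound 4 `CCCn1ccc2cc(-c3ccc(Oc4ccccc4)cc3)cc(Cl)c2c1=O` share another; the difference between the two cores is not broken down here. In a functional assay on CHO cells for agonist activity at metabotropic glutamate receptor 2 (Homo sapiens), read by GTPgammaS binding (a higher number here means that more compound is needed for the effect, a lower number that less compound is needed), compound 1 gives 794 nM. Compound 2 differs from it by phenyl in place of methyl on an oxygen on an aromatic ring and in this assay gives 501 nM, so that a 1.6-fold lower number from compound 1 to compound 2 (0.20 log units; within the scatter). Compound 3 in this assay gives 316 nM. Compound 4 carries the same change on the other core, (phenyl in place of methyl on an oxygen on an aromatic ring), and has not yet been measured in this assay. Resting on the value of compound 3 316 nM and on the earlier step of a 1.6-fold lower number from compound 1 to compound 2 (0.20 log units; within the scatter), the step to compound 4 is expected to be a 1.6-fold lower number from compound 3 to compound 4 (0.20 log units; within the scatter). Compound 4 is therefore estimated at 200 nM in this assay.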

Compound 4, half-maximal effective concentration: 2000 nM
Compound 4: the middle estimate sits 10-fold (1.00 log units) below what was measured; the measured number lies above the stated range.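

On the core of compound 3, methoxy to phenoxy brings a 6.3-fold higher number from compound 3 to compound 4 (0.80 log units; beyond the scatter) in this assay. The change therefore did not carry over from one core to the other, and the two steps differ: the same change on two cores in this assay, a 1.6-fold lower number (0.20 log units; within the scatter) from compound 1 to compound 2 and a 6.3-fold higher number (0.80 log units; beyond the scatter) from compound 3 to compound 4, 10-fold (1.00 log units) apart, beyond the scatter of two such steps. The two pairs show that the outcome of this change depends on the core, but they do not show which feature of the cores is responsible or how the change would behave on a third core.

The compounds shown leave open how an ethyl or benzyl group on the oxygen would compare with methyl and phenyl on either core. They also leave open what an amine in place of the oxygen would do.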